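Swapping the butylamino group of compound 2 for hydrogen

The compounds below may be only part of what the source reports. "The series", "measured", "known", "first", "only" and "open" are said of these compounds alone.

Of the compounds shown here, two sharing one core have been read so far in a functional assay on NCI-H460 cells (Homo sapiens) for cytotoxicity, read by MTT assay, with a stated time of 72 h; a lower number here means a stronger inhibitor, a higher number a weaker inhibitor. Compound 1 (`CCCCCCCCNC1=CC(=O)C=C(C[C@]2(C)[C@@H](C)CC[C@]3(C)C(C)=CCC[C@@H]23)C1=O`), which carries its own amino chain, gives 38000 nM. Compound 2 (`CCCCNC1=CC(=O)C(C[C@]2(C)[C@@H](C)CC[C@]3(C)C(C)=CCC[C@@H]23)=CC1=O`) gives > 100000 nM, and this is a limit of the assay, not a number. Compound 2 therefore has no firm value of its own, and any change from it can only be judged loosely.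

The next compound, compound 3 (`CC1=CCC[C@H]2[C@](C)(CC3=CC(=O)C=CC3=O)[C@@H](C)CC[C@]12C`), has hydrogen in place of butylamino on a double-bonded ring carbon. Going by the values given here, no measured pair shows what such a swap does, so this forecast is a cautious one. Among the compounds with values here, the only firm number nearby belongs to compound 1, at 38000 nM, and a result in that region or somewhat stronger seems the most reasonable expectation. That means a moderate move toward stronger inhibition, well beyond the usual scatter. The expected change is an at least 6.6-fold lower number from compound 2 to compound 3 (0.82 log units; beyond the scatter). Compound 3 is estimated at 15000 nM, with an expected range from 3000 nM to 60000 nM.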

Compound 3, half-maximal inhibitory concentration: 84000 nM
Compound 3: the middle estimate sits 5.6-fold (0.75 log units) below what was measured; the whole stated range lies below it.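

Compound 3 gives this series a firm number for a ring with no amino chain on its double-bonded carbon, and that makes one real comparison possible. In this assay, octylamino and hydrogen can be set side by side, and the result is a 2.2-fold higher number from compound 1 to compound 3 (0.34 log units; beyond the scatter), a modest step that leaves the hydrogen compound the weaker of the two. The swap of butylamino for hydrogen gives only an at least 1.1-fold lower number from compound 2 to compound 3 (0.07 log units; that floor lies within the scatter), which cannot show whether that swap changes anything, as compound 2 has a limit rather than a number: the limit of > 100000 nM in this assay, at which 1 of the 3 values shown sits.

Compound 1 and compound 2 differ in more than one place, so these results cannot show how the length of the chain alone matters. Also open, as far as these compounds go, is how a methylamino group, a morpholine or a hydroxyl group would read on a double-bonded ring carbon of this shared core, and whether any of them would come closer to the octylamino compound or go beyond it.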